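Notes on the isobutyl to 2-(methylsulfanyl)ethyl step

A few compounds are considered here, and "the series" means these few. Any claim that something is new, unique, unknown or untested is made for them only; others in the source may bear on it.

Within the data shown here, in a functional assay on Fem-X cells (Homo sapiens) for cytotoxicity, read by MTT assay, with a stated time of 72 h (a lower number here means a stronger inhibitor, a higher number a weaker inhibitor), only two compounds carry numbers so far. Compound 1 (`CC1=CCC[C@H]2[C@](C)(CC3=CC(=O)C=C(N[C@@H](CC(C)C)C(=O)O)C3=O)[C@@H](C)CC[C@]12C`) gives 10900 nM in this read-out. Compound 2 (`CC(C)C[C@H](NC1=CC(=O)C=C(C(C)(C)C)C1=O)C(=O)O`) gives 39400 nM here, the higher of the two numbers, and its gap to compound 1 lies beyond the usual scatter. Compound 2 is therefore the weaker of the pair.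

Compound 3 (`CSCC[C@H](NC1=CC(=O)C=C(C(C)(C)C)C1=O)C(=O)O`) has not yet been measured. It departs from compound 2 at one place: (methylsulfanyl)methyl in place of isopropyl on a saturated chain carbon, two bonds along the chain from an amine nitrogen and a carbonyl carbon with (methylsulfanyl)methyl in place of isopropyl on a saturated chain carbon, two bonds along the chain from an amine nitrogen and a carbonyl carbon. The same difference can be read as isobutyl to 2-(methylsulfanyl)ethyl.

Among the measured compounds shown here, no measured pair shows this change, so the data offer no direct precedent for it. The expectation in this assay is therefore a small step at most, with no change beyond the scatter, and the starting point is compound 2 at 39400 nM in this series. The expected change a 1.2-fold lower number from compound 2 to compound 3 (0.08 log units; within the scatter) stays within that scatter. For compound 3 the estimated value is 33000 nM with an expected range from 16000 nM to 70000 nM in this assay.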

Compound 3, half-maximal inhibitory concentration: 34800 nM
Estimate against measurement, compound 3: 1.1-fold (0.02 log units) below; measured number inside the range.
By their numbers in this assay, from the lowest: compound 1; then compounds 3 and 2 (each within the scatter of the next).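

In this assay the isobutyl to 2-(methylsulfanyl)ethyl change reads as a 1.1-fold lower number from compound 2 to compound 3 (0.05 log units; within the scatter) and gives the series its first direct reading on a saturated chain carbon, two bonds along the chain from an amine nitrogen and a carbonyl carbon. The (methylsulfanyl)methyl group brings in a sulfur atom and a hydrogen-bond acceptor in place of isopropyl, yet with the rest of the structure held constant, this read-out does not separate the two side chains, so a sulfur-containing chain is accommodated here without a step beyond the scatter. No independent measurement accompanies this result to account for the two side chains reading alike.

On these data alone, whether an amine, a carboxylic acid or a longer chain at this carbon would move the number beyond the scatter remains open, since the two groups compared here are both uncharged chains. Also open, as far as these compounds go, is whether the same change would read alike on the larger scaffold of compound 1 at 10900 nM in this assay or would give a different step there.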